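Shortening the acyl chain of an adenosine ester

This account rests on a few compounds, and the source may have more. Where it says the series, first, only, none or still open, it means among the compounds named here.

Measured compounds:
compound 1 `CC(C)(C)C(=O)OC[C@H]1O[C@@H](n2cnc3c(N)ncnc32)[C@@H](O)[C@@H]1O`, 1.63
compound 2 `CCCCCCCC(=O)OC[C@H]1O[C@@H](n2cnc3c(N)ncnc32)[C@@H](O)[C@@H]1O`, >= 2 (a limit of the method)
compound 3 `CC(=O)OC[C@H]1O[C@@H](n2cnc3c(N)ncnc32)[C@@H](O)[C@@H]1O`, 0.12

Three esters of a shared core have been measured in a physicochemical assay for lipophilicity, using the shake flask method, in phosphate buffer, with a stated time of 1 h; on this read-out lower numbers stand for lower lipophilicity and higher numbers for higher lipophilicity. Compound 1 gives 1.63 and compound 3 gives 0.12. For compound 2 only a limit is known, >= 2, because its reading sits at the limit of >= 2 in this assay, at which 1 of the 3 values shown sits; where compound 2 truly stands above that point is not known.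

The measured steps are all large or at least modest: a number 1.51 log units lower from compound 1 to compound 3 (beyond the scatter), a number at least 1.88 log units lower from compound 2 to compound 3 (beyond the scatter), and a number at least 0.37 log units higher from compound 1 to compound 2 (beyond the scatter). Within these three compounds a shorter acyl group went with a lower partition coefficient.

Compound 4 `CC(C)CC(=O)OC[C@H]1O[C@@H](n2cnc3c(N)ncnc32)[C@@H](O)[C@@H]1O` is not yet measured. It differs from compound 2 by isopropyl in place of hexyl on a saturated chain carbon bound to a carbonyl carbon. The steps from compound 2 to compound 3 and from compound 1 to compound 3 both bear on this change, and a drop is expected, though a smaller one, since isobutyl is larger than the methyl of compound 3. Compound 4 is therefore expected to give 1.45, between 1.05 and 1.85, close to the value of compound 1 and meaning an estimated a number at least 0.55 log units lower from compound 2 to compound 4 (beyond the scatter).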

Compound 4, partition coefficient: 1.39
Estimate against measurement, compound 4: 0.06 log units above; the range from low to high includes it.
By their numbers in this assay, from the lowest: compound 3; then compounds 4 and 1 (each within the scatter of the next). At a limit, above all of these: compound 2.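

In this assay, exchanging the tert-butyl on a carbonyl carbon for isobutyl gives a number 0.24 log units lower from compound 1 to compound 4 (within the scatter), so these two branched groups cannot be told apart here. On the saturated chain carbon bound to a carbonyl carbon, isopropyl in place of hydrogen gives a number 1.27 log units higher from compound 3 to compound 4 (beyond the scatter), whereas isopropyl in place of hexyl gives a number at least 0.61 log units lower from compound 2 to compound 4 (beyond the scatter), so the group at this one place can move the reading either way. Compound 2 stands at a limit, not at a true number: the limit of >= 2 in this assay, at which 1 of the 4 values shown sits.

From the compounds shown here alone, how far compound 2 truly lies from compound 4 remains unknown. Going by these compounds, it is also open how a butyl group, a cyclohexyl ring, or an amine or a carboxylic acid on this same chain carbon would read.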